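Triazole chain extension on a sulfonamide hydroxamate

The source may hold more compounds than are shown below. What is called first, only, known or untested is meant among the compounds shown, and "the series" means these compounds.

Compounds measured so far:
compound 1, `COc1ccc(S(=O)(=O)N(CCN=[N+]=[N-])[C@@H](C(=O)NO)C(C)C)cc1`, 6 nM
compound 2, `COc1ccc(S(=O)(=O)N(CCn2cc(CCCF)nn2)[C@@H](C(=O)NO)C(C)C)cc1`, 0.07 nM

Within the data shown here, in an assay on isolated protein for inhibition of matrix metalloproteinase-9 (Homo sapiens), read by fluorescence, with a stated time of 30 min (on this read-out higher numbers stand for weaker inhibition and lower numbers for stronger inhibition), compound 2 gives 0.07 nM, the lowest of the two numbers known; the only neighbour is compound 1, reached by an 86-fold lower number from compound 1 to compound 2 (1.93 log units; beyond the scatter). Compound 3, `COc1ccc(S(=O)(=O)N(CCn2cc(CCCCOc3cccnc3F)nn2)[C@@H](C(=O)NO)C(C)C)cc1`, differs from compound 2 by ((2-fluoropyridin-3-yl)oxy)methyl in place of fluoro on a saturated chain carbon, three bonds along the chain from an aromatic carbon. Among the measured compounds shown here, no measured step touches that part of the molecule: the single step recorded, from compound 1 to compound 2, replaced the azide with the whole triazole chain and is therefore of a different kind, so it offers no direct guide. For the measured compounds named here, with no step on the chain end to lean on, the expectation for compound 3 is a number close to that of compound 2, and the step from compound 2 to compound 3 is estimated as a 1.4-fold higher number from compound 2 to compound 3 (0.15 log units; within the scatter). For compound 3 in this assay the estimate is 0.1 nM, within 0.02 nM to 0.6 nM.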

Compound 3, half-maximal inhibitory concentration: 0.3 nM
For compound 3 the middle estimate is 3.0-fold (0.48 log units) below the measured one; the range from low to high includes it.
By their numbers in this assay, from the lowest: compound 2; then compound 3; then compound 1.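

Among these compounds, for the first time the chain end itself changes, on a saturated chain carbon, three bonds along the chain from an aromatic carbon, and in this assay there is a 4.3-fold higher number from compound 2 to compound 3 (0.63 log units; beyond the scatter) when ((2-fluoropyridin-3-yl)oxy)methyl replaces fluoro. The position therefore responds to this change, yet the step is only modest for a group that brings a six-membered aromatic ring, and compound 3 still gives 0.3 nM in this read-out. Nothing available accounts for the size of this step.

The compounds shown leave open how much of the step belongs to the ring, to the ether oxygen or to the added chain length. A chain end bearing a plain phenyl ether or a hydroxyl group, or a longer chain ending in fluoro, would help to separate these parts.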